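The source may hold more compounds than are shown below. What is called first, only, known or untested is meant among the compounds shown, and "the series" means these compounds.

Measured compounds:

Compound 1, `COc1ccc(-c2cc(O)c3c(C)cc(C)nc3n2)cc1`: 42700 nM
Compound 2, `COc1cccc(-c2cc(O)c3c(C)ccnc3n2)c1`: 28.8 nM
Compound 3, `COc1ccc(-c2cc(O)c3ccc(C)nc3n2)cc1`: 89100 nM

All three were tested in a functional assay on SF-295 cells (Homo sapiens); a higher number here means a weaker inhibitor of growth, a lower number a stronger inhibitor of growth. Compound 1 and compound 3 share a core; compound 3 carries the change hydrogen in place of methyl on an aromatic carbon relative to compound 1, and that change gave a 2.1-fold higher number from compound 1 to compound 3 (0.32 log units; beyond the scatter). Compound 2 is built on a different core, and the difference between its core and that of compound 1 is not broken down here. What the values show is that compound 2 is far ahead of both: its number in this assay is much lower than those of compound 1 and compound 3.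

Compound 4, `COc1cccc(-c2cc(O)c3cccnc3n2)c1`, has not yet been measured. It differs from compound 2 by hydrogen in place of methyl on an aromatic carbon. For the measured compounds named here, this is the same kind of change as the one from compound 1 to compound 3, though not the same: around the place in compound 1 there is also a methyl group, the place being meta to a methyl group (1 heavy atom), whereas compound 2 has no such neighbour at that place.

Going by the values given here, the expectation for compound 4 therefore rests on the one measured example. Because compound 3 showed a 2.1-fold higher number from compound 1 to compound 3 (0.32 log units; beyond the scatter), a step of similar size, a 2.1-fold higher number from compound 2 to compound 4 (0.32 log units; beyond the scatter), is expected from compound 2 to compound 4 in this assay, starting from the value of compound 2, 28.8 nM. From the compounds shown here alone, whether a change of this kind behaves the same way on the core of compound 2 is unknown, so the range is kept wide. Compound 4 is estimated at 60 nM, expected to fall between 20 nM and 200 nM.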

Compound 4, concentration for 50% growth inhibition: 52.5 nM
Estimate against measurement, compound 4: 1.1-fold (0.06 log units) above; the measured number falls inside the stated range.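

In this assay, replacing the methyl group with hydrogen on the aromatic carbon opposite the ring nitrogen gave a 1.8-fold higher number from compound 2 to compound 4 (0.26 log units; within the scatter) and so leaves compound 2 and compound 4 indistinguishable in this measurement. Set beside the earlier step, the same swap gave closely matching results on the two cores: the same change on two cores in this assay, a 2.1-fold higher number (0.32 log units; beyond the scatter) from compound 1 to compound 3 and a 1.8-fold higher number (0.26 log units; within the scatter) from compound 2 to compound 4, 1.1-fold (0.06 log units) apart, within the scatter of two such steps. For the compounds shown here, this suggests that the step measured on one core was a fair guide to the step on the other, but it rests on only two pairs, and one of those two steps cannot be told apart from ordinary scatter, so it does not establish a rule for any further core.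

The numbers of compound 2 and compound 4 lie far from those of compound 1 and compound 3, but these compounds differ from one another in more than one place, so what accounts for that large gap remains open. Also open, from the compounds shown here alone, is what would happen if this aromatic carbon carried an ethyl group, a longer chain or an amine instead of hydrogen or methyl.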